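A few compounds are considered here, and "the series" means these few. Any claim that something is new, unique, unknown or untested is made for them only; others in the source may bear on it.

In a physicochemical assay for solubility, read by nephelometry, in phosphate buffer, measured as kinetic solubility, at pH 6.5 (on this read-out higher numbers stand for higher solubility and lower numbers for lower solubility), compound 3 `CCc1cccc(CNC(=O)c2nc3cccc(COCc4ccc(C(=O)O)cc4)c3c(=O)[nH]2)c1` gives < 1.6 ug/mL, which is a limit of the assay and not a number. Compound 1 `O=C(O)c1ccc(CCOc2c(F)ccc3nc(C(=O)NCC4CCCCC4)[nH]c(=O)c23)cc1` gives < 1.6 ug/mL, which is also a limit. Compound 2 `CCc1cccc(CNC(=O)c2nc3ccc(F)c(OCCc4ccc(C(=O)O)cc4)c3c(=O)[nH]2)c1` gives a true reading of 12.5 ug/mL.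

The next compound, compound 4 `CCc1cncc(CNC(=O)c2nc3cccc(COCc4ccc(C(=O)O)cc4)c3c(=O)[nH]2)c1`, carries 5-ethylpyridin-3-yl in place of 3-ethylphenyl on a saturated chain carbon bound to an amide-type nitrogen.

Among the compounds with values here, no measured step makes this exact swap. Within the data shown here, the closest evidence is the one measured step at the same place, where 3-ethylphenyl replaces cyclohexyl: an at least 7.8-fold higher number from compound 1 to compound 2 (0.89 log units; beyond the scatter). That step lies beyond the scatter and shows that the group at this place can shift the read-out, but it involves a different pair of groups and a different remainder of the molecule. It therefore offers only a loose guide to size and direction.

On that basis, a modest upward move is expected, and a reading that stays at the limit remains quite possible. The expected change is an at least 2.5-fold higher number from compound 3 to compound 4 (0.39 log units; beyond the scatter). For compound 4, the estimated value is 4 ug/mL, with an expected range from 1.6 ug/mL to 16 ug/mL.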

Compound 4, solubility: 1.6 ug/mL
Estimate against measurement, compound 4: 2.5-fold (0.40 log units) above, within the range that was stated.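

In this assay, placing 5-ethylpyridin-3-yl in place of 3-ethylphenyl on a saturated chain carbon bound to an amide-type nitrogen gives a number no lower from compound 3 to compound 4 (the limit leaves the size open), so the direction is bounded but the size of this step cannot be read. Within the data shown here, the one earlier step at this place, from cyclohexyl to 3-ethylphenyl, was measured on a different remainder of the molecule, whereas this pair shares the core of compound 3 and differs only in a ring carbon exchanged for a nitrogen, which adds 1 hydrogen-bond acceptor while the heavy-atom count stays at 8. This exchange shows no drop in the read-out on this core, yet the reading of compound 4 does not move clear of the lowest part of the scale: the limit of < 1.6 ug/mL in this assay, at which 2 of the 4 values shown sit.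

Going by these compounds, it remains open whether the same exchange would change the reading on the remainder of compound 2, which gives 12.5 ug/mL. Also open, on these data alone, is how the read-out would respond at this place to a ring that carries an amine or a longer chain in place of the ethyl group.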